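The source may hold more compounds than are shown below. What is called first, only, known or untested is meant among the compounds shown, and "the series" means these compounds.

Measured compounds:
compound 1, `CCCc1cc(Cn2c(CC)nc3c(C)cc(C)nc32)cc(CCC)c1OC(C(=O)O)c1ccc(CC)cc1`: 240 nM
compound 2, `CCCc1cc(Cn2c(CC)nc3c(C)cc(C)nc32)cc(CCC)c1OC(C(=O)O)c1ccccc1Cl`: 3500 nM
compound 3, `CCCc1cc(Cn2c(CC)nc3c(C)cc(C)nc32)cc(CCC)c1OC(C(=O)O)c1ccc(Cl)cc1`: 450 nM

In an assay on isolated protein for displacement of a labelled ligand from Type-2 angiotensin II receptor (Rattus norvegicus) (on this read-out higher numbers stand for weaker inhibition and lower numbers for stronger inhibition), compound 2 gives the highest of the three numbers. Its nearest neighbour is compound 3, with a 7.8-fold lower number from compound 2 to compound 3 (0.89 log units; beyond the scatter), and the furthest is compound 1, since going the other way there was a 15-fold higher number from compound 1 to compound 2 (1.16 log units; beyond the scatter). Compound 4, `CCCc1cc(Cn2c(CC)nc3c(C)cc(C)nc32)cc(CCC)c1OC(C(=O)O)c1ccc(C)cc1`, has not yet been measured in this assay. Its difference from compound 2 is: 4-methylphenyl in place of 2-chlorophenyl on a saturated chain carbon bound to a carbonyl carbon and an oxygen on an aromatic ring.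

Going by the values given here, two measured steps bear on this change. Moving the chlorine from the 2-position to the 4-position, from compound 2 to compound 3, lowered the number markedly, and compound 1, carrying 4-ethylphenyl, stands even lower; the step from compound 1 to compound 3, a 1.9-fold higher number from compound 1 to compound 3 (0.27 log units; within the scatter), lies within the scatter, so the 4-substituted phenyls behave alike. Compound 4 is therefore expected to land near compounds 1 and 3, as a step of a 12-fold lower number from compound 2 to compound 4 (1.07 log units; beyond the scatter). The estimate for compound 4 is 300 nM, in the range 120 nM to 800 nM.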

Compound 4, half-maximal inhibitory concentration: 400 nM
Beside the measured number, compound 4's estimate is 1.3-fold (0.12 log units) below it; the measured number falls inside the stated range.
By their numbers in this assay, from the lowest: compounds 1, 4 and 3 (each within the scatter of the next); then compound 2.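

With 4-methylphenyl on the saturated chain carbon, the gap remains large (an 8.8-fold lower number from compound 2 to compound 4 (0.94 log units; beyond the scatter)) in this assay, so a chlorine is not needed for a 4-substituted phenyl to give a much lower number than 2-chlorophenyl. Exchanging chloro for methyl makes no difference that can be read (a 1.1-fold lower number from compound 3 to compound 4 (0.05 log units; within the scatter)). Shortening ethyl to methyl likewise stays within the scatter (a 1.7-fold higher number from compound 1 to compound 4 (0.22 log units; within the scatter)), so ethyl, methyl and chloro at the 4-position cannot be told apart here. What sets 2-chlorophenyl apart cannot be explained from these data, which offer no supporting findings. On these data alone, it remains open whether 2-methylphenyl would behave like 2-chlorophenyl, and how unsubstituted phenyl or a larger 4-substituent such as 4-methoxy or 4-tert-butyl would compare.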